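Swapping Isopropyl for 3-Chlorobenzyl on the Ring Oxygen

This account rests on a few compounds, and the source may have more. Where it says the series, first, only, none or still open, it means among the compounds named here.

Compound 1 `CCOC(=O)c1c(C)nc(-c2cccc(C#N)c2)n1OC(C)C` — 6740 nM
Compound 2 `CCOC(=O)c1c(C)nc(-c2cccc(C#N)c2)n1OCCCO` — 11400 nM
Compound 3 `CCOC(=O)c1c(C)nc(-c2cccc(C#N)c2)n1OCc1ccccc1Cl` — 8710 nM

In a functional assay on a cell-free system (plasma, Oryctolagus cuniculus) for inhibition, with stated times of 5 min, 1 min and 6 min (on this read-out lower numbers stand for stronger inhibition and higher numbers for weaker inhibition), compound 1 holds the lowest of the three numbers, yet both of its gaps stay inside the scatter: a 1.3-fold higher number from compound 1 to compound 3 (0.11 log units; within the scatter) and a 1.7-fold higher number from compound 1 to compound 2 (0.23 log units; within the scatter). Compound 4 `CCOC(=O)c1c(C)nc(-c2cccc(C#N)c2)n1OCc1cccc(Cl)c1` is not yet measured. It differs from compound 1 by 3-chlorobenzyl in place of isopropyl on an oxygen on an aromatic ring. The step from compound 1 to compound 3 bears most directly on it, as that step likewise places a chlorobenzyl group on an oxygen on an aromatic ring, and it remained within the scatter; the step to compound 2, with a very different group entering, did the same. Compound 4 is therefore expected to show no step beyond the scatter in this assay, an expected step of a 1.2-fold higher number from compound 1 to compound 4 (0.07 log units; within the scatter). The estimate for compound 4 is 8000 nM, ranging from 3500 nM to 18000 nM.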

Compound 4, half-maximal inhibitory concentration: 19400 nM
Beside the measured number, compound 4's estimate is 2.4-fold (0.38 log units) below it; the whole stated range lies below it.
By their numbers in this assay, from the lowest: compounds 1, 3, 2 and 4 (each within the scatter of the next, the first and the last beyond it).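

In this assay, for the compounds shown here, 3-chlorophenyl in place of 2-chlorophenyl gives a 2.2-fold higher number from compound 3 to compound 4 (0.35 log units; beyond the scatter) and so shows that the place of the chlorine matters here, which the earlier compounds could not show. 3-chlorobenzyl in place of isopropyl gives a 2.9-fold higher number from compound 1 to compound 4 (0.46 log units; beyond the scatter) as the first step from compound 1 to pass the scatter, while the step from the 3-hydroxypropyl group, a 1.7-fold higher number from compound 2 to compound 4 (0.23 log units; within the scatter), does not. Nothing available accounts for these differences.

The compounds shown leave open how an unsubstituted benzyl, a 4-chlorobenzyl or a 3-methoxybenzyl group on this oxygen would compare.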